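The compounds below may be only part of what the source reports. "The series", "measured", "known", "first", "only" and "open" are said of these compounds alone.

Measured so far:
compound 1, `CC(C)(C)OC(=O)Nc1cccc(-c2csc(NC(=O)CCCCCC(=O)NO)n2)c1`, 5.7 nM
compound 2, `CC(C)(C)OC(=O)Nc1cccc(-c2csc(NC(=O)CCCCCC(=O)Nc3ccccc3N)n2)c1`, 5300 nM

In an assay on isolated protein for inhibition of polyamine deacetylase HDAC10 (Homo sapiens), read by fluorescence, with a stated time of 17 h (on this read-out lower numbers stand for stronger inhibition and higher numbers for weaker inhibition), compound 1 gives 5.7 nM, the lowest of the two numbers in hand. Compound 2 gives 5300 nM, and the two are separated by a 930-fold higher number from compound 1 to compound 2 (2.97 log units; beyond the scatter). Compound 3, `Nc1cccc(-c2csc(NC(=O)CCCCCC(=O)NO)n2)c1`, is still to be measured. It differs from compound 1 as hydrogen in place of tert-butoxycarbonyl on a nitrogen on an aromatic ring, while the hydroxy on the amide-type nitrogen of compound 1 is kept. Going by the values given here, the only measured step, a 930-fold higher number from compound 1 to compound 2 (2.97 log units; beyond the scatter), concerns the amide-type nitrogen and not the tert-butoxycarbonyl, so no measured step bears directly on this change; the data give no precedent for it. With the hydroxy group retained, the expected step of a 1.6-fold higher number from compound 1 to compound 3 (0.20 log units; within the scatter) is small, within or close to the scatter, in no firm direction. Compound 3 is therefore estimated at 9 nM, in the range 2 nM to 40 nM.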

Compound 3, half-maximal inhibitory concentration: 3.7 nM
The estimate for compound 3 lay 2.4-fold (0.39 log units) above the measured number, within the range that was stated.
By their numbers in this assay, from the lowest: compounds 3 and 1 (each within the scatter of the next); then compound 2.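

In this assay, hydrogen in place of tert-butoxycarbonyl on a nitrogen on an aromatic ring gives a 1.5-fold lower number from compound 1 to compound 3 (0.19 log units; within the scatter), so at this position the whole carbamate group can go without a change beyond the scatter. Going by these compounds alone, the only earlier step, a 930-fold higher number from compound 1 to compound 2 (2.97 log units; beyond the scatter), concerned the amide-type nitrogen, so this is the first reading at the nitrogen on the aromatic ring, and it is small where that step was large. No supporting measurement accounts for this lack of response to the change.

On these data alone, whether an acetyl or a methyl on this nitrogen would read like the free amino group remains open. Also open, as far as these compounds go, is whether the same lack of response would hold with 2-aminophenyl in place of the hydroxy, or with a longer chain.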